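Swapping trifluoromethyl for fluoro on two related cores

The compounds below may be only part of what the source reports. "The series", "measured", "known", "first", "only" and "open" are said of these compounds alone.

This account follows three measured compounds and one that awaits measurement. Compound 1 `Fc1ccc(Nc2cc3[nH]c(Nc4ccc(N5CCNCC5)cn4)nc3cn2)cc1C(F)(F)F` gives 14000 nM in an ADME assay on CHO cells (Cricetulus griseus) for cytotoxicity, read by MTT assay; on this read-out lower numbers stand for higher toxicity in this test and higher numbers for lower toxicity in this test. Compound 2 `Fc1ccc(Nc2cc3[nH]c(Nc4ccc(N5CCNCC5)cn4)nc3cn2)cc1F` is its partner in a single change, (fluoro in place of trifluoromethyl on an aromatic carbon), and in this assay compound 2 gives 33000 nM, so that the step of a 2.4-fold higher number from compound 1 to compound 2 (0.37 log units; beyond the scatter). Compound 3 `O=C(c1ccnc(Nc2nc3cnc(Nc4ccc(F)c(C(F)(F)F)c4)cc3[nH]2)c1)N1CCN(C2CC2)CC1` is built on a different core; the difference between the two cores is not broken down here. In this assay compound 3 gives 30000 nM.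

Compound 4 `O=C(c1ccnc(Nc2nc3cnc(Nc4ccc(F)c(F)c4)cc3[nH]2)c1)N1CCN(C2CC2)CC1` carries the same change relative to compound 3, namely (fluoro in place of trifluoromethyl on an aromatic carbon), and the surroundings of that change read the same in both pairs. Compound 4 has not yet been measured in this assay. Because the step of a 2.4-fold higher number from compound 1 to compound 2 (0.37 log units; beyond the scatter) was modest and beyond the scatter, a step of similar size is expected here, so the estimate means a step of a 1.8-fold higher number from compound 3 to compound 4 (0.26 log units; within the scatter). Compound 4 is therefore expected to give about 55000 nM in this assay, an estimate that rests on one prior pair only.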

Compound 4, half-maximal cytotoxic concentration: > 50000 nM
Compound 4: only a limit was reported; the forecaster's own chance of this, stated with the estimate: 15%; the middle value lies beyond the limit too.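

Carried onto the core of compound 3, the change from 4-fluoro-3-(trifluoromethyl)phenyl to 3,4-difluorophenyl gives, in this assay, an at least 1.6-fold higher number from compound 3 to compound 4 (0.22 log units; that floor lies within the scatter). In this assay compound 4 gives > 50000 nM, which is a limit of the assay and not a number. The numbers point the same way on both cores, but the floor of the new step lies within the scatter, so a real rise on the second core is not established, and neither equal nor different step sizes are shown: the same change on two cores in this assay, a 2.4-fold higher number (0.37 log units; beyond the scatter) from compound 1 to compound 2 and an at least 1.6-fold higher number (0.22 log units; that floor lies within the scatter) from compound 3 to compound 4; the limit leaves it open whether they differ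

The compounds shown leave open how the numbers in this assay would read with chloro, methoxy or nitrile in place of fluoro at this position, on either core. They also leave open whether the step would hold on a third core, since the comparison here rests on two pairs alone, one of which ends in a limit.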